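Swapping hydroxy for dimethylamino on the compound 1 scaffold

A few compounds are considered here, and "the series" means these few. Any claim that something is new, unique, unknown or untested is made for them only; others in the source may bear on it.

In a functional assay on A2780 cells (Homo sapiens) for antiproliferative activity, read by MTT assay, with a stated time of 48 h (a higher number here means a weaker inhibitor, a lower number a stronger inhibitor), compound 1 (`COc1ccc(C(=O)c2ccc3c(c2)C=CC(C)(C)O3)c(NC(=O)CO)c1`) gives 130 nM, the lowest number in the set and the strongest result so far. Compound 2 (`CCNCC(=O)Nc1cc(OC)ccc1C(=O)c1ccc(OC)c2c1OC(C)(C)C=C2`) gives 1980 nM and compound 3 (`COc1ccc(C(=O)c2ccc(OC)c3c2C=CC(C)(C)O3)c(NC(=O)CN(C)C)c1`) gives 3990 nM, both beyond the scatter from compound 1. Compound 4 (`COc1ccc(C(=O)c2ccc3c(c2)C=CC(C)(C)O3)c(NC(=O)CN(C)C)c1`) keeps the core of compound 1 and has dimethylamino in place of hydroxy on a saturated chain carbon bound to a carbonyl carbon. Within the data shown here, no measured pair isolates this change. Among the measured compounds shown here, the only guide is compound 3, which also carries dimethylamino and gives 3990 nM. A loss of potency beyond the scatter is therefore expected, with an estimated 5.4-fold higher number from compound 1 to compound 4 (0.73 log units; beyond the scatter). For compound 4 the estimated value is 700 nM, with an expected range of 180 nM to 2800 nM.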

Compound 4, half-maximal inhibitory concentration: 1020 nM
Compound 4: the middle estimate sits 1.5-fold (0.16 log units) below what was measured, and the stated range covers the measured number.
By their numbers in this assay, from the lowest: compound 1; then compounds 4, 2 and 3 (each within the scatter of the next, the first and the last beyond it).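

In this assay, among these compounds, the step of a 7.8-fold higher number from compound 1 to compound 4 (0.89 log units; beyond the scatter) is the first to isolate this change, with the core of compound 1 held constant. At this place, on a saturated chain carbon bound to a carbonyl carbon, hydroxy therefore gives the lower number, and dimethylamino costs potency beyond the scatter. No measurement here bears on the cause of this loss.

Still open, going by these compounds, is how other groups at this place compare with hydroxy and dimethylamino, for example a primary amine, a carboxylic acid or a longer hydroxyalkyl chain.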